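Hydroxypropyl amide on the trimethoxy core: expected tolerance

The source may report more compounds than this note shows. Statements on the series, on what has been measured and on what is new or still open speak of the compounds shown alone.

The compounds measured so far in an ADME assay on Vero cells (Chlorocebus sabaeus) for cytotoxicity (a lower number here means that less compound is tolerated, a higher number that more compound is tolerated), are:
compound 1 `COc1ccc(-c2nc3c(C(=O)Nc4ccccc4F)cccc3[nH]2)cc1OC`, where compound 1 gives 24.5 uM
compound 2 `COc1ccc(-c2nc3c(C(=O)NCCCO)cccc3[nH]2)cc1OC`, where compound 2 gives 46 uM
compound 3 `COc1ccc(-c2nc3c(C(=O)Nc4ccccc4F)cccc3[nH]2)c(OC)c1OC`, where compound 3 gives 37.8 uM

Compound 2 differs from compound 1 in one place, (3-hydroxypropyl in place of 2-fluorophenyl on an amide-type nitrogen). That change brought a 1.9-fold higher number from compound 1 to compound 2 (0.27 log units; within the scatter). Compound 3 differs from compound 1 in its core, (methoxy in place of hydrogen on an aromatic carbon), which brought a 1.5-fold higher number from compound 1 to compound 3 (0.19 log units; within the scatter). Compound 3 stands with compound 2 and compound 1 within the usual scatter on both sides, so no order among the three can be read from these numbers.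

Compound 4 `COc1ccc(-c2nc3c(C(=O)NCCCO)cccc3[nH]2)c(OC)c1OC` has not yet been measured in this assay. It differs from compound 3 by 3-hydroxypropyl in place of 2-fluorophenyl on an amide-type nitrogen. The place of this change is worded exactly as for the change from compound 1 to compound 2, so it is the same change, now made on the core of compound 3 rather than the core of compound 1.

In this assay the step from compound 3 to compound 4 is expected to be a 1.6-fold higher number from compound 3 to compound 4 (0.20 log units; within the scatter), which rests on the earlier step of a 1.9-fold higher number from compound 1 to compound 2 (0.27 log units; within the scatter) and on the starting number of compound 3, 37.8 uM. The expectation is tentative, as that earlier step lies within the scatter and was seen only once. Compound 4 is therefore estimated at 60 uM in this assay, with a likely range from 30 uM to 120 uM.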

Compound 4, half-maximal toxic concentration: 40 uM
The estimate for compound 4 lay 1.5-fold (0.18 log units) above the measured number; the measured number falls inside the stated range.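

In this assay, 3-hydroxypropyl in place of 2-fluorophenyl on an amide-type nitrogen gave a 1.1-fold higher number from compound 3 to compound 4 (0.02 log units; within the scatter), and methoxy in place of hydrogen on an aromatic carbon gave a 1.2-fold lower number from compound 2 to compound 4 (0.06 log units; within the scatter). The amide change, set on two cores, shows no difference between them that can be told from scatter: the same change on two cores in this assay, a 1.9-fold higher number (0.27 log units; within the scatter) from compound 1 to compound 2 and a 1.1-fold higher number (0.02 log units; within the scatter) from compound 3 to compound 4, 1.8-fold (0.25 log units) apart, within the scatter of two such steps. The methoxy change reads the same way, and with every step here within the scatter, the four compounds show neither that these changes carry over unchanged from one core to another nor that either change has any real effect of its own in this assay: the same change on two cores in this assay, a 1.5-fold higher number (0.19 log units; within the scatter) from compound 1 to compound 3 and a 1.2-fold lower number (0.06 log units; within the scatter) from compound 2 to compound 4, 1.8-fold (0.25 log units) apart, within the scatter of two such steps.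

The compounds shown leave open whether another group on the amide-type nitrogen, such as a chain ending in an amine, a carboxylic acid or a longer chain than 3-hydroxypropyl, would move the number beyond the scatter on either core. For the compounds shown here, each change has also been seen on only two cores, so how it behaves on any further core remains an open question.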